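The source may hold more compounds than are shown below. What is called first, only, known or untested is meant among the compounds shown, and "the series" means these compounds.

Measured so far in an ADME assay on COS-7 cells (Chlorocebus aethiops) for cytotoxicity, read by MTT assay, with a stated time of 24 h; a higher number here means that more compound is tolerated, a lower number that less compound is tolerated:
- compound 1 `CCOC(=O)c1c(CN2CCCCC2)nc2ccc(Cl)cc2c1-c1ccccc1` gives 311000 nM
- compound 2 `CCOC(=O)c1c(CN2CCN(C)CC2)nc2ccc(Cl)cc2c1-c1ccccc1` gives 35900 nM

Compound 2 holds the lower of the two numbers in this assay. Compound 3 `CCOC(=O)c1c(CN2CCCC2)nc2ccc(Cl)cc2c1-c1ccccc1` differs from it at a saturated chain carbon bound to an aromatic carbon, with pyrrolidin-1-yl in place of 4-methylpiperazin-1-yl (pyrrolidin-1-yl in place of 4-methylpiperazin-1-yl on a saturated chain carbon bound to an aromatic carbon). For the measured compounds named here, one measured step bears on this: an 8.7-fold lower number from compound 1 to compound 2 (0.94 log units; beyond the scatter), where 4-methylpiperazin-1-yl took the place of piperidin-1-yl at the same carbon. Compound 3 also lacks the 4-methylpiperazin-1-yl, so a step of similar size in the opposite direction, towards a higher number, is expected. Going by the values given here, no measured compound carries pyrrolidin-1-yl, so the range stays wide. The expected step is a 5.0-fold higher number from compound 2 to compound 3 (0.70 log units; beyond the scatter). For compound 3 the estimated value is 180000 nM, with an expected range from 60000 nM to 450000 nM.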

Compound 3, half-maximal cytotoxic concentration: 490000 nM
The estimate for compound 3 lay 2.7-fold (0.43 log units) below the measured number; the whole stated range lies below it.
By their numbers in this assay, from the lowest: compound 2; then compounds 1 and 3 (each within the scatter of the next).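

Replacing 4-methylpiperazin-1-yl with pyrrolidin-1-yl on the saturated chain carbon gives a large change in this assay (a 14-fold higher number from compound 2 to compound 3 (1.14 log units; beyond the scatter)), whereas pyrrolidin-1-yl and piperidin-1-yl cannot be told apart there (a 1.6-fold higher number from compound 1 to compound 3 (0.20 log units; within the scatter)). Among these three compounds, the lower number therefore goes with 4-methylpiperazin-1-yl alone, and the change from pyrrolidin-1-yl to piperidin-1-yl at this carbon does not shift the result beyond the scatter. No evidence is available on what lies behind these differences.

From the compounds shown here alone, it remains open whether the second ring nitrogen or its methyl group goes with the lower number, a question that piperazin-1-yl without the methyl or morpholin-4-yl would address. An open-chain diethylamino group at the same carbon also remains to be placed against these rings.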